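From 3-(trifluoromethyl)phenyl to 4-(trifluoromethyl)phenyl

The compounds below may be only part of what the source reports. "The series", "measured", "known", "first", "only" and "open" are said of these compounds alone.

Of the compounds shown here, three built on a shared core have been measured in a functional assay on HCT-116 cells (Homo sapiens) for antiproliferative activity, read by MTT assay, with a stated time of 72 h; on this read-out higher numbers stand for weaker inhibition and lower numbers for stronger inhibition. There, compound 1 (`CC(C)c1cccc(NC(=O)CCc2cccc3c2B(O)OC3)c1`) gives 1600 nM, compound 2 (`COc1cc(OC)cc(-c2cccc(NC(=O)CCc3cccc4c3B(O)OC4)c2)c1`) gives 53 nM and compound 3 (`O=C(CCc1cccc2c1B(O)OC2)Nc1cccc(-c2cccc(C(F)(F)F)c2)c1`) gives 580 nM, the second highest of the three numbers. Compound 4 (`O=C(CCc1cccc2c1B(O)OC2)Nc1cccc(-c2ccc(C(F)(F)F)cc2)c1`) carries 4-(trifluoromethyl)phenyl in place of 3-(trifluoromethyl)phenyl on an aromatic carbon.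

Three measured steps change the group at this place. The step of a 2.8-fold lower number from compound 1 to compound 3 (0.44 log units; beyond the scatter) is modest, whereas a 30-fold lower number from compound 1 to compound 2 (1.48 log units; beyond the scatter) and an 11-fold higher number from compound 2 to compound 3 (1.04 log units; beyond the scatter) are large. Each of them exchanges one group for a different one, so none shows what moving the trifluoromethyl group does. The large step of an 11-fold higher number from compound 2 to compound 3 (1.04 log units; beyond the scatter) nevertheless argues for a wide range. Among the compounds with values here, with no measured precedent for either direction, no change beyond the scatter is expected, and the expected step is a 1.1-fold lower number from compound 3 to compound 4 (0.02 log units; within the scatter). For compound 4 the estimated value is 550 nM, with an expected range from 170 nM to 1800 nM.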

Compound 4, half-maximal inhibitory concentration: 550 nM
Compound 4: the middle estimate sits on the measured number at the digits printed; the range from low to high includes it.
By their numbers in this assay, from the lowest: compound 2; then compounds 4 and 3 (each within the scatter of the next); then compound 1.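

Exchanging 3-(trifluoromethyl)phenyl for 4-(trifluoromethyl)phenyl gives a 1.1-fold lower number from compound 3 to compound 4 (0.02 log units; within the scatter) in this assay, so this read-out does not separate these two groups at this place. The distances to the other groups stay large or modest as before, with a 10-fold higher number from compound 2 to compound 4 (1.02 log units; beyond the scatter) and a 2.9-fold lower number from compound 1 to compound 4 (0.46 log units; beyond the scatter), so the gap to 3,5-dimethoxyphenyl does not depend on which of these two trifluoromethyl-bearing groups is present. Nothing measured alongside these compounds bears on the result.

The compounds shown leave open whether a phenyl carrying one methoxy group would stand closer to compound 2 or to compound 4, and so how much of the gap belongs to the second methoxy group. They also leave open how an amine or a carboxylic acid on that phenyl would read in this assay.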